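This account rests on a few compounds, and the source may have more. Where it says the series, first, only, none or still open, it means among the compounds named here.

Of the compounds shown here, two have numbers so far in a functional assay on MGC-803 cells (Homo sapiens) for cytotoxicity, read by MTT assay, with a stated time of 48 h; on this read-out lower numbers stand for stronger inhibition and higher numbers for weaker inhibition. Compound 1 (`CC1=NN(C(=O)c2ccc([N+](=O)[O-])cc2)C(c2ccccc2O)C1`) gives 50000 nM. Compound 2 (`CC1=NN(C(=O)CCl)C(c2cc(Br)ccc2O)C1`) gives 13500 nM, the lowest of the two numbers, and its gap to compound 1 lies beyond the scatter.

Compound 3 (`CC1=NN(C(=O)COc2ccc(Cl)cc2)C(c2cc(Br)ccc2O)C1`) is the next one to be read against compound 2. The change is 4-chlorophenoxy in place of chloro on a saturated chain carbon bound to a carbonyl carbon.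

Within the data shown here, no two measured compounds differ in one place only, so no measured step speaks directly to this change. The working expectation in this assay is therefore no step beyond the scatter, with no direction favoured, and with wide uncertainty on both sides. Among the measured compounds shown here, the only guide to how far numbers move is the spread from compound 1 at 50000 nM to compound 2 at 13500 nM. The expected step is a 1.0-fold higher number from compound 2 to compound 3 (0.02 log units; within the scatter). For compound 3 the estimated value is 14000 nM, with an expected range from 3000 nM to 50000 nM.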

Compound 3, half-maximal inhibitory concentration: 23600 nM
The estimate for compound 3 lay 1.7-fold (0.23 log units) below the measured number; measured number inside the range.
By their numbers in this assay, from the lowest: compounds 2 and 3 (each within the scatter of the next); then compound 1.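

Placing 4-chlorophenoxy in place of chloro on a saturated chain carbon bound to a carbonyl carbon gives a 1.7-fold higher number from compound 2 to compound 3 (0.24 log units; within the scatter) in this assay and provides the first comparison in the series that differs in one place only. At this position, a single chlorine atom gives way to a group of eight heavy atoms, bringing a six-membered aromatic ring and a hydrogen-bond acceptor, without a change in the number that can be read apart from the scatter, so this one pair shows that the larger group is accommodated here in this cytotoxicity read-out and that it brings no gain over chloro. No measurement at hand offers an explanation for this flat step.

Going by these compounds, whether any other group on this chain carbon moves the number beyond the scatter remains open, and an amine such as morpholine or a carboxylic acid would test this with a group quite unlike the two compared here. On these data alone, it also remains open whether the chlorine of the 4-chlorophenoxy group or the ether oxygen contributes to the number, which plain phenoxy or a longer chain carrying the same ring would begin to separate.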